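Series notes: methoxy to trifluoromethoxy on compound 3

This account rests on a few compounds, and the source may have more. Where it says the series, first, only, none or still open, it means among the compounds named here.

Compound 1 (`C=C(Br)C(=O)Nc1cccc(/C=C/C(=O)Nc2ccc(Cl)cc2)c1`), compound 2 (`C=C(Br)C(=O)Nc1cccc(/C=C/C(=O)Nc2ccc(C)cc2)c1`) and compound 3 (`C=C(Br)C(=O)Nc1cccc(/C=C/C(=O)Nc2ccc(OC)cc2)c1`) share one core and differ in a single group on an aromatic carbon. In a functional assay on CCRF-CEM cells (Homo sapiens) for inhibition, read by MTT assay, with a stated time of 72 h (a lower number here means a stronger inhibitor, a higher number a weaker inhibitor), compound 1 gives 460 nM while compound 2 gives 270 nM and compound 3 gives 26 nM on the same read-out. Compound 3 has the lowest number of the three, with both gaps beyond the scatter.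

Compound 4 (`C=C(Br)C(=O)Nc1cccc(/C=C/C(=O)Nc2ccc(OC(F)(F)F)cc2)c1`) differs from compound 3 in one place, by trifluoromethyl in place of methyl on an oxygen on an aromatic ring as trifluoromethyl in place of methyl on an oxygen on an aromatic ring. For the measured compounds named here, no measured pair makes this change directly. The closest evidence is methoxy replacing another group on an aromatic carbon: an 18-fold lower number from compound 1 to compound 3 (1.25 log units; beyond the scatter) and a 10-fold lower number from compound 2 to compound 3 (1.02 log units; beyond the scatter) are both large and both go downward. Going by the values given here, the one step without methoxy (a 1.7-fold lower number from compound 1 to compound 2 (0.23 log units; within the scatter)) stays within the scatter. Among the compounds with values here, with compound 3 at 26 nM as the only methoxy member, the change to trifluoromethoxy is expected to give back much of that gain, though not necessarily all of it. An upward move beyond the scatter is expected, estimated as a 6.9-fold higher number from compound 3 to compound 4 (0.84 log units; beyond the scatter) in these notes. The expected value for compound 4 is 180 nM (50 nM to 600 nM as the estimated range).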

Compound 4, half-maximal inhibitory concentration: 13000 nM
Compound 4: middle estimate off by 72-fold (1.86 log units), on the low side; the measured number lies above the stated range.
By their numbers in this assay, from the lowest: compound 3; then compounds 2 and 1 (each within the scatter of the next); then compound 4.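

In this assay, the oxygen on the aromatic ring does not by itself go with the low number of compound 3: with trifluoromethyl in place of methyl on that oxygen, the result is a large move upward (a 500-fold higher number from compound 3 to compound 4 (2.70 log units; beyond the scatter)), so what is bound to the oxygen matters at this position. The earlier compounds shown here showed only downward steps of this size, whereas compound 4 also stands well above both members without an oxygen there (a 48-fold higher number from compound 2 to compound 4 (1.68 log units; beyond the scatter); a 28-fold higher number from compound 1 to compound 4 (1.45 log units; beyond the scatter)), making trifluoromethoxy the highest-number group of the four and widening the range the position can produce. Nothing shown accounts for the size of these steps.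

Going by these compounds, it remains open whether the upward move belongs to the three fluorines together or would already appear with a single fluorine on that methyl, and how an ethyl or a longer chain on the same oxygen would read. A hydroxyl or an amine on the same aromatic carbon would show whether compound 3 depends on the methyl on oxygen or on the oxygen with any small group.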